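This account rests on a few compounds, and the source may have more. Where it says the series, first, only, none or still open, it means among the compounds named here.

Going by the values given here, of the two numbers so far in a functional assay on the whole organism for inhibition, with Mus musculus as the target (on this read-out higher numbers stand for an effect only at larger amounts of compound and lower numbers for an effect already at smaller amounts), compound 1 (`CCC1CCSC1=O`) stands higher, at 414 mg/kg, while compound 2 (`CC(C)C1CCSC1=O`) gives 145 mg/kg. That single measured step, a 2.9-fold lower number from compound 1 to compound 2 (0.46 log units; beyond the scatter), swapped a hydrogen on a saturated chain carbon for methyl. Compound 3 (`CCC1(CC)CCSC1=O`) differs from compound 1 elsewhere: ethyl in place of hydrogen on a saturated ring carbon, with ethyl in place of hydrogen on a saturated ring carbon. Among the compounds with values here, the step to compound 2 is the only guide, and a loose one, since the place differs. The expected change is again modest and toward a lower number, a 3.2-fold lower number from compound 1 to compound 3 (0.50 log units; beyond the scatter). For compound 3 the estimated value is 130 mg/kg, with an expected range of 55 mg/kg to 300 mg/kg.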

Compound 3, dose for half-maximal effect: 104 mg/kg
For compound 3 the middle estimate is 1.3-fold (0.10 log units) above the measured one; the range from low to high includes it.
By their numbers in this assay, from the lowest: compounds 3 and 2 (each within the scatter of the next); then compound 1.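

In this assay ethyl in place of hydrogen on this saturated ring carbon, two ring bonds from the ring sulfur, gives a 4.0-fold lower number from compound 1 to compound 3 (0.60 log units; beyond the scatter) and is the first step shown at this place. So a change on the ring carbon itself, and not only on the chain, can shift the number toward an effect at smaller amounts. Nothing measured here says why this happens.

Going by these compounds, whether a longer chain such as propyl, an amine or a carboxylic acid at this ring carbon would lower the number further or raise it stays open. A single change at this place cannot show a trend.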